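Two Inactive Analogues and a Third Carrying an Ester

The source may report more compounds than this note shows. Statements on the series, on what has been measured and on what is new or still open speak of the compounds shown alone.

Measured compounds:
Compound 1 `C#CCN1CCN(CC(=O)N2CCN(c3ccc(C(=O)c4cc5ccc(N(CC)CC)cc5o4)cc3)CC2)CC1`: > 40000 nM
Compound 2 `CCN(CC)c1ccc2cc(C(=O)c3ccc(N4CCN(C(=O)CN5CCN(Cc6ccc(C#N)cc6)CC5)CC4)cc3)oc2c1`: > 40000 nM

In a functional assay on HeLa cells (Homo sapiens) for cytotoxicity, read by MTT assay, with a stated time of 48 h (on this read-out higher numbers stand for weaker inhibition and lower numbers for stronger inhibition), compound 1 gives only a limit, > 40000 nM. In this assay compound 2 likewise gives only a limit, > 40000 nM. The step that the two limits leave unreadable from compound 1 to compound 2 therefore cannot be sized, and compound 2 stands at the limit, as does every value shown, as the limit of > 40000 nM in this assay, at which 2 of the 2 values shown sit, records. Compound 3 `CCOC(=O)CN1CCN(CC(=O)N2CCN(c3ccc(C(=O)c4cc5ccc(N(CC)CC)cc5o4)cc3)CC2)CC1` is not yet measured; it differs from compound 2 by ethoxycarbonyl in place of 4-cyanophenyl on a saturated chain carbon bound to an amine nitrogen in a ring. No measured step reads on this change, since the only shown step is unreadable. Given that compound 2 sits at > 40000 nM, compound 3 is expected to give a limit again or a value near it in this assay. The estimated step is a step that the limit leaves unreadable from compound 2 to compound 3, none beyond the scatter. Compound 3 is estimated at 60000 nM, with a range from 20000 nM to 200000 nM.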

Compound 3, half-maximal inhibitory concentration: 22100 nM
The estimate for compound 3 lay 2.7-fold (0.43 log units) above the measured number, and the stated range covers the measured number.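

Among these compounds, with ethoxycarbonyl on a saturated chain carbon bound to an amine nitrogen in a ring, compound 3 gives in this assay the first value at this position that is a number and not a limit, 22100 nM. The data give an at least 1.8-fold lower number from compound 2 to compound 3 (0.25 log units; that floor lies within the scatter) and an at least 1.8-fold lower number from compound 1 to compound 3 (0.25 log units; that floor lies within the scatter), so this change brings the read-out within the measurable range, yet neither floor goes beyond the scatter and no real difference from the 4-cyanophenyl or the ethynyl compound is established. The other two values remain limits of the assay: the limit of > 40000 nM in this assay, at which 2 of the 3 values shown sit.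

From the compounds shown here alone, it remains open whether ethoxycarbonyl truly separates from those two groups, as the true size of both steps is unknown. Also open, going by these compounds, is how the read-out would respond to a carboxylic acid or an amide in place of ethoxycarbonyl, or to a longer chain carrying it.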